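The source may hold more compounds than are shown below. What is called first, only, known or untested is meant among the compounds shown, and "the series" means these compounds.

Working notes on the series. In an assay on CHO cells for antagonist activity at transient receptor potential cation channel subfamily V member 1 (Homo sapiens), read by FLIPR (on this read-out lower numbers stand for stronger inhibition and higher numbers for weaker inhibition), compound 1 `CC(C(=O)NCc1ccc(C(F)(F)F)nc1-c1cccc(Cl)c1)c1ccc(NS(C)(=O)=O)c(F)c1` gives 0.5 nM, and compound 2 `CC(C(=O)NCc1ccc(C(F)(F)F)nc1-c1ccc(N(C)C)cc1)c1ccc(NS(C)(=O)=O)c(F)c1` gives 3.2 nM. For the measured compounds named here, compound 2 stands highest of the two numbers so far; its only neighbour is compound 1, separated by a 6.4-fold higher number from compound 1 to compound 2 (0.81 log units; beyond the scatter) through 4-(dimethylamino)phenyl in place of 3-chlorophenyl on an aromatic carbon. Compound 3 `Cc1cc(-c2nc(C(F)(F)F)ccc2CNC(=O)C(C)c2ccc(NS(C)(=O)=O)c(F)c2)ccc1F` has not yet been measured in this assay. It differs from compound 2 by 4-fluoro-3-methylphenyl in place of 4-(dimethylamino)phenyl on an aromatic carbon. Going by the values given here, the sole measured step at this position is the one from compound 1 to compound 2, which ran toward the 4-(dimethylamino)phenyl and its one hydrogen-bond acceptor; compound 3 goes back to a phenyl with no hydrogen-bond acceptor, so the number is expected to fall again by about that size, a 4.0-fold lower number from compound 2 to compound 3 (0.60 log units; beyond the scatter). Compound 3 is therefore estimated at 0.8 nM in this assay, with a range of 0.3 nM to 2.5 nM.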

Compound 3, inhibition constant: 0.4 nM
Compound 3: the middle estimate sits 2.0-fold (0.30 log units) above what was measured; low and high end bracket the measured number.
By their numbers in this assay, from the lowest: compounds 3 and 1 (each within the scatter of the next); then compound 2.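

In this assay, the change to 4-fluoro-3-methylphenyl on the aromatic carbon next to the ring nitrogen gives an 8.0-fold lower number from compound 2 to compound 3 (0.90 log units; beyond the scatter), so the rise seen with 4-(dimethylamino)phenyl does not extend to every substituted phenyl at this position. For the compounds shown here, the second new step, a 1.3-fold lower number from compound 1 to compound 3 (0.10 log units; within the scatter), shows that 4-fluoro-3-methylphenyl and 3-chlorophenyl cannot be told apart here, which leaves 4-(dimethylamino)phenyl as the only one of the three groups that stands apart. Nothing available bears on the cause of these differences.

The three compounds do not separate the contributions of the fluorine and the methyl in compound 3. They also leave open whether the higher number of compound 2 would persist with a 4-methoxyphenyl, a 4-aminophenyl or an unsubstituted phenyl at this position.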